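This account rests on a few compounds, and the source may have more. Where it says the series, first, only, none or still open, it means among the compounds named here.

Compound 1 `O=C(NCC1CCOCC1)c1cnc(Nc2cccc(F)c2)cc1C1CC1` gives 125 ug/mL in a physicochemical assay for solubility, at pH 7.4 (on this read-out lower numbers stand for lower solubility and higher numbers for higher solubility), the higher of the two measured numbers. Compound 2 `O=C(NCC1CCOCC1)c1cnc(Nc2cccc(Br)c2)cc1C1CC1` gives 45 ug/mL in this assay, and a 2.8-fold lower number from compound 1 to compound 2 (0.44 log units; beyond the scatter). Compound 3 `O=C(NCC1CCOCC1)c1cnc(Nc2cccc(OC(F)(F)F)c2)cc1C1CC1` differs from compound 1 by trifluoromethoxy in place of fluoro on an aromatic carbon. Among the compounds with values here, the single step that bears on this change is the one from compound 1 to compound 2, a modest drop beyond the scatter. A drop of at least similar size is expected here, because a 2.8-fold lower number from compound 1 to compound 2 (0.44 log units; beyond the scatter) went the same way for a heavier substituent on that carbon. For compound 3 the expected step is a 4.2-fold lower number from compound 1 to compound 3 (0.62 log units; beyond the scatter). Compound 3 is therefore estimated at 30 ug/mL, within 10 ug/mL to 80 ug/mL.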

Compound 3, solubility: < 1 ug/mL
Compound 3 gave a limit, no number; the forecaster's own chance of this, stated with the estimate: 5%; middle value at least 30-fold (1.47 log units) from the limit.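

In this assay, trifluoromethoxy on this aromatic carbon brings an at least 120-fold lower number from compound 1 to compound 3 (2.09 log units; beyond the scatter) and an at least 45-fold lower number from compound 2 to compound 3 (1.65 log units; beyond the scatter). Both steps are large, so this position can tolerate far less change than the modest step from fluoro to bromo alone suggested. Compound 3 gives a limit of the assay and not a number: the limit of < 1 ug/mL in this assay, at which 1 of the 3 values shown sits.

Going by these compounds, how far compound 3 lies past that limit stays open. So does whether a steep fall belongs to trifluoromethoxy alone, or would also follow an amine or a carboxylic acid on this carbon.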